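Swapping a methoxy for chloro on a pyrazoline aryl

A few compounds are considered here, and "the series" means these few. Any claim that something is new, unique, unknown or untested is made for them only; others in the source may bear on it.

Measured compounds:
compound 1 `COc1ccc(C2=NN(c3nc(-c4ccc(OC)cc4)cs3)C(c3ccc4c(c3)OCCO4)C2)cc1` – 3010 nM
compound 2 `COc1ccc(C2=NN(c3nc(-c4ccc(Br)cc4)cs3)C(c3ccc4c(c3)OCCO4)C2)cc1` – 2520 nM
compound 3 `Cc1ccc(C2=NN(c3nc(-c4ccc(Br)cc4)cs3)C(c3ccc4c(c3)OCCO4)C2)cc1` – 1680 nM

All three share one core and were tested in a functional assay on B16-F10 cells (Mus musculus) for antiproliferative activity, read by MTT assay, with a stated time of 48 h; a higher number here means a weaker inhibitor, a lower number a stronger inhibitor. Compound 1 has the highest number of the three, but its gaps to compound 2 and to compound 3 are both within the scatter, so no order among them can be claimed. The two measured steps are a 1.2-fold lower number from compound 1 to compound 2 (0.08 log units; within the scatter) and a 1.5-fold lower number from compound 2 to compound 3 (0.18 log units; within the scatter); each changes one group on a six-membered aromatic ring of carbon only, and neither moves the number beyond the scatter.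

Compound 4 `COc1ccc(-c2csc(N3N=C(c4ccc(Cl)cc4)CC3c3ccc4c(c3)OCCO4)n2)cc1` differs from compound 1 by chloro in place of methoxy on an aromatic carbon, that is, 4-methoxyphenyl to 4-chlorophenyl. Among the measured compounds shown here, of the measured steps, the one from compound 2 to compound 3 is the closest guide, since it also replaces a methoxy on the same kind of ring and stays within the scatter; the step from compound 1 to compound 2 swaps a methoxy for a halogen, likewise within the scatter. With no measured change here larger than the scatter, compound 4 is expected to show a step of about a 1.2-fold lower number from compound 1 to compound 4 (0.08 log units; within the scatter), which is no step beyond the scatter. The estimate for compound 4 in this assay is 2500 nM, with a range from 1200 nM to 5500 nM.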

Compound 4, half-maximal inhibitory concentration: 3120 nM
Compound 4: the middle estimate sits 1.2-fold (0.10 log units) below what was measured, within the range that was stated.
By their numbers in this assay, from the lowest: compounds 3, 2, 1 and 4 (each within the scatter of the next).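

In this assay, the exchange of 4-methoxyphenyl for 4-chlorophenyl gives a 1.0-fold higher number from compound 1 to compound 4 (0.02 log units; within the scatter), so here the methoxy can give way to chloro, with its hydrogen-bond acceptor gone and one heavy atom fewer, without a step beyond the scatter. The same ring also lost its methoxy in the step to methyl, a 1.5-fold lower number from compound 2 to compound 3 (0.18 log units; within the scatter), which was measured with a bromo on the far aryl ring rather than a methoxy; two different replacements on two different backgrounds have therefore stayed within the scatter at this position, although chloro and methyl are never compared directly. Nothing available explains why the number holds steady here.

On these data alone, whether a more different group on this ring, such as an amine or a carboxylic acid, would move the number beyond the scatter remains open. Also open, as far as these compounds go, is whether chloro at this position would behave the same way with a bromo in place of the other methoxy, as in compound 2.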